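Series notes: bromo analogue of compound 1

The source may hold more compounds than are shown below. What is called first, only, known or untested is meant among the compounds shown, and "the series" means these compounds.

Measured so far:
compound 1 `CCOC(=O)C1=C(C)N(c2ccccc2)C=CC1c1ccccc1`: -29.3%
compound 2 `CCOC(=O)C1=C(C)N(c2ccc(F)cc2)C=CC1c1ccccc1`: -25.5%

In a functional assay, tested at 200 ug/mL (on this read-out higher numbers stand for a weaker effect at the one concentration tested and lower numbers for a stronger effect), compound 1 gives -29.3%, the lowest of the two numbers recorded. Its nearest neighbour is compound 2, which in this assay gives -25.5%. Within the data shown here, the single step joining them, a number 3.8 percentage points higher from compound 1 to compound 2 (within the scatter), lies within the scatter, so the two compounds cannot be ordered on this read-out.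

Compound 3 `CCOC(=O)C1=C(C)N(c2ccc(Br)cc2)C=CC1c1ccccc1` has not been measured. It differs from compound 1 by bromo in place of hydrogen on an aromatic carbon. Among the measured compounds shown here, the only measured step that bears on this change is a number 3.8 percentage points higher from compound 1 to compound 2 (within the scatter), which puts fluoro at the same place and stays within the scatter. Bromo at that place is expected to do much the same, so no step beyond the scatter is expected in this assay; the expected step is a number 3.3 percentage points higher from compound 1 to compound 3 (within the scatter). Compound 3 is therefore estimated at -26%, with a range from -42% to -10%.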

Compound 3, a percentage reported as activity, at one concentration (the size of the read-out at that concentration, not a potency): -35.7%
Estimate against measurement, compound 3: 9.7 percentage points above, within the range that was stated.
By their numbers in this assay, from the lowest: compounds 3, 1 and 2 (each within the scatter of the next, the first and the last beyond it).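

In this assay, bromo in place of hydrogen at this position, para to a large group, gives a step that again stays inside the scatter, (a number 6.4 percentage points lower from compound 1 to compound 3 (within the scatter)), so neither halogen separates from the unsubstituted compound 1. Among these compounds, the new information lies in the comparison between the halogens: (a number 10.2 percentage points lower from compound 2 to compound 3 (beyond the scatter)) is the first step at this position to pass beyond the scatter, and it is modest. Exchanging one halogen for the other can therefore shift this read-out, even though compound 1 cannot be ordered against either halogen compound, and no available data explain the step.

Three compounds leave open whether groups other than halogens, such as an amine, a carboxylic acid or a longer alkyl chain, would move this assay further at this position. On these data alone, whether the same exchange of bromo for fluoro behaves alike elsewhere on the shared core also remains open.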